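This account rests on a few compounds, and the source may have more. Where it says the series, first, only, none or still open, it means among the compounds named here.

Measured so far:
compound 1, `Cc1cccc(CNc2ncnc3c2ncn3[C@@H]2O[C@H](CO)[C@@H](O)[C@H]2O)c1`: > 166000 nM
compound 2, `Cc1ccc(O)c(CNc2ncnc3c2ncn3[C@@H]2O[C@H](CO)[C@@H](O)[C@H]2O)c1`: 16500 nM

In a functional assay on K562 cells (Homo sapiens) for antiproliferative activity, with a stated time of 72 h (on this read-out lower numbers stand for stronger inhibition and higher numbers for weaker inhibition), compound 1 gives only a limit, > 166000 nM, so its number is not known. Compound 2 gives 16500 nM in this assay. Within the data shown here, the one measured step, an at least 10-fold lower number from compound 1 to compound 2 (1.00 log units; beyond the scatter), concerns hydroxy in place of hydrogen on an aromatic carbon and does not touch the change now followed. Compound 3, `OC[C@H]1O[C@@H](n2cnc3c(NCc4cccc(C(F)(F)F)c4)ncnc32)[C@H](O)[C@@H]1O`, differs from compound 1 by trifluoromethyl in place of methyl on an aromatic carbon. Among the measured compounds shown here, no measured step bears on this change, and compound 1 stands at the limit of > 166000 nM in this assay, at which 1 of the 2 values shown sits, so neither size nor direction of the step in this assay can be read from the data. Compound 3 is therefore expected to stay near the limit, with an at least 1.1-fold lower number from compound 1 to compound 3 (0.04 log units; that floor lies within the scatter) as the estimated step. Compound 3 is estimated at 150000 nM, between 30000 nM and 500000 nM, and a limit rather than a number is the likelier outcome.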

Compound 3, half-maximal inhibitory concentration: > 166000 nM
Compound 3 gave a limit, no number; the forecaster's own chance of this, stated with the estimate: 60%; middle value at least 1.1-fold (0.04 log units) from the limit.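

In this assay compound 3 gives only a limit, > 166000 nM, and not a number. Compound 1 also gives only a limit, so the step between the two cannot be read, and trifluoromethyl in place of methyl on this aromatic carbon, meta to a large group, does not bring a number into reach in this assay: the limit of > 166000 nM in this assay, at which 2 of the 3 values shown sit. Among these compounds, the one readable comparison is an at least 10-fold higher number from compound 2 to compound 3 (1.00 log units; beyond the scatter), which leaves compound 2 as the only one of the three with a number.

As far as these compounds go, how far compound 1 and compound 3 actually lie past the limit stays open, as does any order between them. Also open, from the compounds shown here alone, is whether an amine or a carboxylic acid at this position, or a hydroxy added to the 3-(trifluoromethyl)phenyl group, would give a number.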